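The source may hold more compounds than are shown below. What is called first, only, known or untested is meant among the compounds shown, and "the series" means these compounds.

Compound 1 `COc1cc(-c2nnc3n2NC(c2ccco2)C(C(=O)c2ccc(Cl)cc2)S3)cc(OC)c1OC` gives 78600 nM in a functional assay on HepG2 cells (Homo sapiens) for cytotoxicity, read by MTT assay, with a stated time of 48 h; a higher number here means a weaker inhibitor, a lower number a stronger inhibitor.
Compound 2 `COc1cc(-c2nnc3n2NC(c2cccs2)C(C(=O)c2ccccc2)S3)cc(OC)c1OC` gives only a limit in this assay, > 100000 nM.

Going by the values given here, compound 1 is thus the only compound with a number in this assay; the other value sits at the limit of > 100000 nM in this assay, at which 1 of the 2 values shown sits. Compound 3 `COc1cc(-c2nnc3n2NC(c2ccco2)C(C(=O)c2cccc4ccccc24)S3)cc(OC)c1OC` differs from compound 1 by naphthalen-1-yl in place of 4-chlorophenyl on a carbonyl carbon. Among the compounds with values here, with no measured pair showing this change, the step of a 1.1-fold lower number from compound 1 to compound 3 (0.05 log units; within the scatter) is expected to be of no size beyond the scatter. Compound 3 is accordingly estimated at 70000 nM, with a range from 25000 nM to 200000 nM, and a limit rather than a number would not be surprising.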

Compound 3, half-maximal inhibitory concentration: 33900 nM
The estimate for compound 3 lay 2.1-fold (0.31 log units) above the measured number; measured number inside the range.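

The group on this carbonyl carbon can move the number in this assay: the change gives a 2.3-fold lower number from compound 1 to compound 3 (0.37 log units; beyond the scatter), modest but the first readable step among these compounds. Compound 2 gives only a limit and so adds no step: the limit of > 100000 nM in this assay, at which 1 of the 3 values shown sits.

The one change both removes the chlorine and adds a second six-membered aromatic ring, and the compounds shown do not separate these two differences. They also leave open how a 4-methoxyphenyl or a simple methyl group would read on the same carbonyl carbon.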